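Compound 3 and the limit reached by compound 2

This account rests on a few compounds, and the source may have more. Where it says the series, first, only, none or still open, it means among the compounds named here.

Measured so far in a functional assay on CEM13 cells (Homo sapiens) for cytotoxicity, read by MTT assay, with a stated time of 72 h; a lower number here means a stronger inhibitor, a higher number a weaker inhibitor
- compound 1 `Cc1c(C)c2c(c(C)c1OC(=O)CCC(=O)NC1CC(C)(C)N([O])C(C)(C)C1)CC[C@@](C)(CCC[C@H](C)CCC[C@H](C)CCCC(C)C)O2` gives 146000 nM
- compound 2 `Cc1c(C)c2c(c(C)c1OC(=O)CCC(=O)NC1CC(C)(C)N([O])C1(C)C)CC[C@@](C)(CCC[C@H](C)CCC[C@H](C)CCCC(C)C)O2` gives > 300000 nM (a limit and not a number)

Compound 2 has no number of its own and stands at the limit of > 300000 nM in this assay, at which 1 of the 2 values shown sits. Compound 3 `Cc1c(C)c2c(c(C)c1OC(=O)CCC(=O)NCC1CC(C)(C)N([O])C1(C)C)CC[C@@](C)(CCC[C@H](C)CCC[C@H](C)CCCC(C)C)O2` differs from it by a group of 11 heavy atoms (9 carbon, 1 nitrogen, 1 oxygen; one five-membered non-aromatic ring with 1 hetero atom) in place of a group of 10 heavy atoms (8 carbon, 1 nitrogen, 1 oxygen; one five-membered non-aromatic ring with 1 hetero atom), on an amide-type nitrogen on an amide-type nitrogen, with a group of 11 heavy atoms in place of a group of 10 heavy atoms. Both groups hold one five-membered non-aromatic ring with 1 hetero atom.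

Among the compounds with values here, only one measured step bears on this change, and it is an at least 2.0-fold higher number from compound 1 to compound 2 (0.31 log units; beyond the scatter) in this assay. As far as these compounds go, that step ends on the limit, and its full size stays unknown. The group in compound 3 matches the group in compound 1 in its count of 11 heavy atoms, but its ring stays five-membered rather than six-membered. Only a partial return toward compound 1 is therefore expected, and perhaps no change that can be measured. The expected move is an at least 1.2-fold lower number from compound 2 to compound 3 (0.09 log units; that floor lies within the scatter) in the direction of a lower number. The estimate for compound 3 is 240000 nM with an expected range from 100000 nM to 450000 nM and a real chance of another limit.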

Compound 3, half-maximal inhibitory concentration: 105000 nM
Compound 3: middle estimate off by 2.3-fold (0.36 log units), on the high side; the range from low to high includes it.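

In this assay, replacing the group of 10 heavy atoms on the amide-type nitrogen with the group of 11 heavy atoms, while keeping a five-membered non-aromatic ring, gives an at least 2.8-fold lower number from compound 2 to compound 3 (0.45 log units; beyond the scatter). Ring size alone therefore does not account for the earlier change, since the two groups of 11 heavy atoms, one with a five-membered ring and one with a six-membered ring, give a 1.4-fold lower number from compound 1 to compound 3 (0.14 log units; within the scatter), and this assay does not separate them. Compound 2 is a limit and not a number, and the full size of the step that reaches it stays unknown: the limit of > 300000 nM in this assay, at which 1 of the 3 values shown sits.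

The compounds shown leave open how a larger group on the amide-type nitrogen, such as one holding a seven-membered non-aromatic ring, would read in this assay. They also leave open whether any ring is needed on that nitrogen, as against an open hexyl chain or a simple amine-bearing chain.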